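Chloro to Trifluoromethyl on the Aryl Ring

The compounds below may be only part of what the source reports. "The series", "measured", "known", "first", "only" and "open" are said of these compounds alone.

Compound 1 `COc1cc(F)ccc1-c1cc2c(cn1)ncn2-c1ccc(OC(F)F)cc1` is measured in a functional assay on HL-60 cells (Homo sapiens) for activation, read by flow cytometry, with a stated time of 4 days (a higher number here means that more compound is needed for the effect, a lower number that less compound is needed), and gives 93 nM. Compound 2 `Fc1ccc(-c2cc3c(cn2)ncn3-c2ccc(OC(F)F)cc2)c(Cl)c1` gives 90 nM in this assay. The step of a 1.0-fold lower number from compound 1 to compound 2 (0.01 log units; within the scatter) keeps both numbers together, so compound 2 stands level with compound 1 and neither can be set above the other on the numbers shown.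

Compound 3 `Fc1ccc(-c2cc3c(cn2)ncn3-c2ccc(OC(F)F)cc2)c(C(F)(F)F)c1` differs from compound 2 by a single change: trifluoromethyl in place of chloro on an aromatic carbon.

Within the data shown here, only the step of a 1.0-fold lower number from compound 1 to compound 2 (0.01 log units; within the scatter) bears on this position, and it did not move the number beyond the scatter. Among the measured compounds shown here, there is no measured example of a trifluoromethyl group at this place, so the expectation rests on that one step alone. Compound 3 is therefore expected to remain close to compound 2, with an estimated step of no change at the digits printed from compound 2 to compound 3 (within the scatter) in this assay. The estimate for compound 3 is 90 nM, within a range from 45 nM to 180 nM.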

Compound 3, half-maximal effective concentration: 1500 nM
Compound 3: the middle estimate sits 17-fold (1.22 log units) below what was measured; measured number above the stated range.
By their numbers in this assay, from the lowest: compounds 2 and 1 (each within the scatter of the next); then compound 3.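

The position proves sensitive to the group it carries: in this assay, trifluoromethyl in place of chloro gives a 17-fold higher number from compound 2 to compound 3 (1.22 log units; beyond the scatter) and trifluoromethyl in place of methoxy gives a 16-fold higher number from compound 1 to compound 3 (1.21 log units; beyond the scatter) on the same aromatic carbon. Among these compounds, the agreement of compound 1 and compound 2 within the scatter therefore did not mean that this place accepts any group, since trifluoromethyl is the one group of the three that separates from the others. No measurement at hand explains this rise.

The compounds shown leave open whether a methyl, a bromo or a nitrile at this place would stay with chloro and methoxy or go with trifluoromethyl. They also leave open whether the change would give a step of similar size without the fluoro group on this ring.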